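This account rests on a few compounds, and the source may have more. Where it says the series, first, only, none or still open, it means among the compounds named here.

Working notes on the series. Compound 1 `COc1ccc2[nH]cc(C(=O)c3cc(OC)c(OC)c(OC)c3N)c2c1` and compound 2 `COc1cc2[nH]cc(C(=O)c3cc(OC)c(OC)c(OC)c3N)c2cc1OC` share one core; compound 3 `COc1cc(Cc2c[nH]c3ccccc23)c(N)c(OC)c1OC` and compound 4 `COc1cc(Cc2c[nH]c3c(OC)cccc23)c(N)c(OC)c1OC` share another. How the core of compound 3 differs from the core of compound 1 is not broken down here.

In a functional assay on HT-29 cells (Homo sapiens) for cytotoxicity, read by sulforhodamine B assay, with a stated time of 48 h (on this read-out higher numbers stand for weaker inhibition of growth and lower numbers for stronger inhibition of growth), compound 1 gives 950 nM. In this assay compound 2 gives 24400 nM. The step of a 26-fold higher number from compound 1 to compound 2 (1.41 log units; beyond the scatter) came with methoxy in place of hydrogen on an aromatic carbon. Compound 3 in this assay gives only a limit, > 100000 nM, which is the limit of > 100000 nM in this assay, at which 1 of the 3 values shown sits.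

Compound 4 remains to be measured in this assay. It differs from compound 3 by methoxy in place of hydrogen on an aromatic carbon. The place is not the same as before: there the entering group sat ortho to a methoxy group, meta to a fused ring and para to a fused ring; here it sits ortho to a fused ring and meta to a fused ring. The change is the same kind of change, not the same.

For compound 4 the expected step is a step that the limit leaves unreadable from compound 3 to compound 4. The expectation rests on the limit for compound 3, > 100000 nM. It also rests on the direction of a 26-fold higher number from compound 1 to compound 2 (1.41 log units; beyond the scatter), where this kind of change gave a higher number. Compound 4 is therefore expected at about 200000 nM, most likely again reported only as a limit.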

Compound 4, concentration for 50% growth inhibition: "not active" (no number reported)
Compound 4: no number reported, so the estimate cannot be set against anything.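

In this assay, among these compounds, compound 4 carries no number, so no step from compound 3 to compound 4 can be read. Compound 3 stands only at a limit: the limit of > 100000 nM in this assay, at which 1 of the 4 values shown sits. The compounds shown leave open whether methoxy in place of hydrogen, ortho to a fused ring and meta to a fused ring, changes growth inhibition on this core.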